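Swapping the hydrazone aryl group: from chlorophenyl to indole

This account rests on a few compounds, and the source may have more. Where it says the series, first, only, none or still open, it means among the compounds named here.

Measured compounds:
- compound 1, `CCCSc1nc(N/N=C/c2cccnc2)c2nnn(Cc3ccccc3)c2n1`: 38100 nM
- compound 2, `CCCSc1nc(N/N=C/c2cccc(Cl)c2)c2nnn(Cc3ccccc3)c2n1`: > 64000 nM

Two compounds share a core and differ only in the aryl group on the carbon with a double bond to nitrogen. In a functional assay on MGC-803 cells (Homo sapiens) for antiproliferative activity, read by MTT assay, with a stated time of 72 h (a higher number here means a weaker inhibitor, a lower number a stronger inhibitor), compound 1 gives 38100 nM. Compound 2 reaches only the limit of the assay, > 64000 nM, so no number is known for it; it sits at the limit of > 64000 nM in this assay, at which 1 of the 2 values shown sits. Going by the values given here, the one measured step, an at least 1.6-fold higher number from compound 1 to compound 2 (0.22 log units; that floor lies within the scatter), is therefore a floor and lies within the scatter.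

Compound 3, `CCCSc1nc(N/N=C/c2c[nH]c3ccccc23)c2nnn(Cc3ccccc3)c2n1`, differs from compound 2 as follows: 1H-indol-3-yl in place of 3-chlorophenyl on a carbon with a double bond to nitrogen. Among the compounds with values here, no measured step covers an indole at this place, and the one step known is small. The estimate for compound 3 is a value near the weak end already seen, 40000 nM with a range from 8000 nM to 150000 nM, which would mean an expected step of an at least 1.6-fold lower number from compound 2 to compound 3 (0.20 log units; that floor lies within the scatter).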

Compound 3, half-maximal inhibitory concentration: 7410 nM
Compound 3: the middle estimate sits 5.4-fold (0.73 log units) above what was measured; the whole stated range lies above it.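

Going by these compounds alone, the earlier pair left it unclear whether the aryl group on the carbon with a double bond to nitrogen matters at all, as its only step lay within the scatter. In this assay, the 1H-indol-3-yl group now gives an at least 8.6-fold lower number from compound 2 to compound 3 (0.93 log units; beyond the scatter) and a 5.1-fold lower number from compound 1 to compound 3 (0.71 log units; beyond the scatter), so this position does respond to the choice of group, and both steps lie beyond the scatter. The first of these steps is only a floor, as compound 2 stands at a limit and not at a number: the limit of > 64000 nM in this assay, at which 1 of the 3 values shown sits.

Compared with 3-chlorophenyl, the indole brings in a hydrogen-bond donor and a five-membered aromatic ring, and the compounds shown cannot separate these two changes. A benzofuran group or a pyrrole group at this place would be needed to tell them apart.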